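This account rests on a few compounds, and the source may have more. Where it says the series, first, only, none or still open, it means among the compounds named here.

In a functional assay on U-937 cells (Homo sapiens) for cytotoxicity, read by MTT assay, with a stated time of 3 days (a lower number here means a stronger inhibitor, a higher number a weaker inhibitor), compound 1 `N#Cc1c(Nc2ccccc2)nc(SCc2nc3ccccc3[nH]2)nc1-c1ccccc1` gives 3.28 nM, compound 2 `N#Cc1c(NC(N)=S)nc(SCc2nc3ccccc3[nH]2)nc1-c1ccccc1` gives 20 nM, and compound 3 `N#Cc1c(-c2ccccc2)nc(SCc2nc3ccccc3[nH]2)nc1N1CCNCC1` gives 5.81 nM. Compound 3 therefore belongs with the lower numbers of this small set: the measured steps are a 1.8-fold higher number from compound 1 to compound 3 (0.25 log units; within the scatter), within the scatter, and a 3.4-fold lower number from compound 2 to compound 3 (0.54 log units; beyond the scatter), a modest one beyond it. The next structure is compound 4 `N#Cc1c(-c2ccccc2)nc(SCc2nc3ccccc3[nH]2)nc1N1CCN(S(=O)(=O)c2ccccc2)CC1`, with phenylsulfonyl in place of hydrogen on an amine nitrogen in a ring. Among the compounds with values here, no measured step changes that nitrogen, so the evidence is only indirect. The largest step seen, a 6.1-fold higher number from compound 1 to compound 2 (0.79 log units; beyond the scatter), is still modest, so in this assay little or no change beyond the scatter is expected. The expected step is a 1.2-fold higher number from compound 3 to compound 4 (0.08 log units; within the scatter). For compound 4 the estimated value is 7 nM, with a range of 2 nM to 25 nM.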

Compound 4, half-maximal inhibitory concentration: 6.2 nM
Estimate against measurement, compound 4: 1.1-fold (0.05 log units) above, within the range that was stated.
By their numbers in this assay, from the lowest: compounds 1, 3 and 4 (each within the scatter of the next); then compound 2.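

The earlier compounds shown here all leave hydrogen on the amine nitrogen of the piperazine ring, so they could not show what a large group does there. In this assay, phenylsulfonyl in place of that hydrogen gives a 1.1-fold higher number from compound 3 to compound 4 (0.03 log units; within the scatter), which means this assay cannot tell the two compounds apart. Nothing measured here explains this result. From the compounds shown here alone, it remains open whether a small methyl or acetyl group, or a longer chain ending in a carboxylic acid, would fit this pattern on the same nitrogen.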